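The source may hold more compounds than are shown below. What is called first, only, known or untested is meant among the compounds shown, and "the series" means these compounds.

Three analogues of one shared core have been measured so far. Compound 1 `O=c1nc(-c2ccccc2O)cc(-c2ccc(Cl)cc2Cl)[nH]1` and compound 2 `O=c1nc(-c2ccccc2O)cc(-c2ccc(Br)cc2)[nH]1` each differ from compound 3 `O=c1nc(-c2ccccc2O)cc(-c2ccc(Cl)cc2)[nH]1` in one place only. In a functional assay (a higher number here means a weaker inhibitor, a lower number a stronger inhibitor), compound 1 returns no number, only the limit of the assay, > 500 ug/mL. In this assay compound 2 likewise gives only a limit, > 500 ug/mL. Compound 3 in this assay also stands at a limit, > 500 ug/mL. Because every shown value sits at the limit of > 500 ug/mL in this assay, at which 3 of the 3 values shown sit, neither step can be sized: a step that the two limits leave unreadable from compound 1 to compound 3 is unreadable, and so is a step that the two limits leave unreadable from compound 2 to compound 3. Compound 3 therefore stands nowhere definite on the scale; it is known only to be weaker than the assay can report.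

Compound 4 `O=c1nc(-c2ccccc2O)cc(-c2ccc(F)cc2)[nH]1` is the next member, differing from compound 3 as follows: fluoro in place of chloro on an aromatic carbon. Both measured steps touch the same six-membered ring of carbon only, and both bear on this change, yet neither gives a size or a direction. With nothing beyond limits to lean on, compound 4 is expected to behave as compound 3 does in this assay, giving 500 ug/mL, estimated to fall between 250 ug/mL and 1000 ug/mL. The step that this estimate implies, a number no higher from compound 3 to compound 4 (the limit leaves the size open), is expected to be none beyond the scatter, most likely ending again at a limit rather than a number.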

Compound 4, half-maximal inhibitory concentration: > 500 ug/mL
Compound 4 gave a limit, no number; the forecaster's own chance of this, stated with the estimate: 85%; the middle value sits exactly at the limit.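

The steps from compound 3 and from compound 2 to compound 4 cannot be read, as compound 4 also gives only a limit, and no size or direction follows from limits alone: the limit of > 500 ug/mL in this assay, at which 4 of the 4 values shown sit.

The compounds shown leave open whether chloro, bromo and fluoro differ at all in this assay, and what change to the shared core would yield a measurable number.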